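Difluorobenzyl regiochemistry on the pyrazole arm of compound 2

The compounds below may be only part of what the source reports. "The series", "measured", "known", "first", "only" and "open" are said of these compounds alone.

Compound 1 `CCCn1c(=O)c2nc(-c3ccnn3-c3ccccc3)[nH]c2n(CCC)c1=O`: 1100 nM
Compound 2 `CCCn1c(=O)c2nc(-c3cnn(Cc4c(F)cccc4F)c3)[nH]c2n(CCC)c1=O`: 390 nM
Compound 3 `CCCn1c(=O)c2c(nc(-n3cc(I)cn3)n2Cc2ccccc2)n(CCC)c1=O`: > 5800 nM

In an in vitro assay on HEK293 cells for displacement of a labelled ligand from adenosine receptor A2b (Homo sapiens) (on this read-out lower numbers stand for stronger inhibition and higher numbers for weaker inhibition), compound 2 gives 390 nM and has the lower of the two numbers measured as values. Compound 1 gives 1100 nM in this assay, a higher number, and the gap to compound 2 lies beyond the scatter. Compound 3 gives > 5800 nM in this assay, which is a limit of the assay the limit of > 5800 nM in this assay, at which 1 of the 3 values shown sits, and not a number. Compound 4 `CCCn1c(=O)c2nc(-c3cnn(Cc4cccc(F)c4F)c3)[nH]c2n(CCC)c1=O` is not yet measured. It differs from compound 2 as follows: 2,3-difluorophenyl in place of 2,6-difluorophenyl on a saturated chain carbon bound to an aromatic nitrogen. Among the compounds with values here, no step between measured compounds has this change, so the author expects at most a small step, likely none beyond the scatter, in this assay. For compound 4 the expected value in this assay is 500 nM, between 150 nM and 1600 nM, an expected step of a 1.3-fold higher number from compound 2 to compound 4 (0.11 log units; within the scatter).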

Compound 4, inhibition constant: 240 nM
For compound 4 the middle estimate is 2.1-fold (0.32 log units) above the measured one, and the stated range covers the measured number.
By their numbers in this assay, from the lowest: compounds 4 and 2 (each within the scatter of the next); then compound 1. At a limit, above all of these: compound 3.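

In this assay, within the data shown here, the 2,6-difluorophenyl and 2,3-difluorophenyl groups on the saturated chain carbon bound to an aromatic nitrogen can be compared directly for the first time, and the result is a 1.6-fold lower number from compound 2 to compound 4 (0.21 log units; within the scatter) and so no difference that can be told from the scatter. The earlier compounds shown here differed in more than one place and could not show that this position accepts both arrangements of the two fluorines. Nothing measured here accounts for why the two compounds read alike.

On these data alone, whether an unsubstituted benzyl, a methoxybenzyl or a longer chain would read the same at this position remains open. So does whether a group other than fluorine on the phenyl ring would move the number beyond the scatter.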